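Swapping the Halogen Pattern on the Benzyl Arm

A few compounds are considered here, and "the series" means these few. Any claim that something is new, unique, unknown or untested is made for them only; others in the source may bear on it.

Compound 1 `CCc1nc(Cl)c2n1CCN([C@@H](C(=O)NC)c1ccccc1)[C@H]2COc1ccc(C(F)(F)F)cc1` gives 431 nM in a functional assay on CHO cells for antagonist activity at Orexin/Hypocretin receptor type 1 (Homo sapiens), read by FLIPR and calcium flux; a higher number here means a weaker inhibitor, a lower number a stronger inhibitor.
Compound 2 `CCc1nc(Cl)c2n1CCN([C@@H](C(=O)NC)c1ccccc1)[C@H]2CCc1ccc(C(F)(F)F)c(Cl)c1` gives 20 nM in this assay.

Compound 2 stands at the lowest of the two numbers, set apart by a 22-fold lower number from compound 1 to compound 2 (1.33 log units; beyond the scatter). Compound 3 `CCc1nc(Cl)c2n1CCN([C@@H](C(=O)NC)c1ccccc1)[C@H]2CCc1ccc(C(F)(F)F)cc1F` carries 2-fluoro-4-(trifluoromethyl)phenyl in place of 3-chloro-4-(trifluoromethyl)phenyl on a saturated chain carbon, two bonds along the chain from a saturated ring carbon. Among the measured compounds shown here, the one measured step altered both the link to the ring and its substituents at once, so it offers no direct guide to this halogen swap alone. The step from compound 2 to compound 3 is therefore expected to be modest, a 2.0-fold higher number from compound 2 to compound 3 (0.30 log units; within the scatter), probably within the scatter or slightly weaker. Compound 3 is estimated at 40 nM, in a range from 12 nM to 130 nM.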

Compound 3, half-maximal inhibitory concentration: 45 nM
Estimate against measurement, compound 3: 1.1-fold (0.05 log units) below, and the stated range covers the measured number.
By their numbers in this assay, from the lowest: compound 2; then compound 3; then compound 1.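

In this assay, the halogen change on this aryl arm has a small but real effect, a 2.3-fold higher number from compound 2 to compound 3 (0.35 log units; beyond the scatter), so 2-fluoro-4-(trifluoromethyl)phenyl is tolerated with only a modest loss against 3-chloro-4-(trifluoromethyl)phenyl. A second benzyl arm also reads well under the phenoxy arm, a 9.6-fold lower number from compound 1 to compound 3 (0.98 log units; beyond the scatter), so compound 2 is not alone in this. No evidence at hand bears on the reason for these differences. Still open, going by these compounds, is whether the identity of the halogen or its place sets the gap, since both change together here, and how a nitrile or methoxy group would read on this ring.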